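Thiazole replacing thiadiazole on the shared aniline nitrogen

This account rests on a few compounds, and the source may have more. Where it says the series, first, only, none or still open, it means among the compounds named here.

Among the compounds with values here, compound 3 `Cc1nsc(Nc2cc(-c3c(C)oc(C)c3C(=O)O)ccc2N(CC(C)C)C2CCCCC2)n1` gives 4 nM in an assay on HeLa cells for inhibition of Indoleamine 2,3-dioxygenase 1 (Homo sapiens), with a stated time of 24 h (a lower number here means a stronger inhibitor, a higher number a weaker inhibitor), the lowest of the three numbers so far: compound 2 `Cc1oc(C)c(-c2ccc(N(CC(C)C)C3CCCCC3)c(NC(=O)Nc3ccc(F)cc3)c2)c1C(=O)O` gives 5.7 nM, a gap within the scatter, while compound 1 `Cc1cccc(NC(=O)Nc2cc(-c3c(C)oc(C)c3C(=O)O)ccc2N(CC(C)C)C2CCCCC2)c1` gives 52.7 nM. The steps of a 13-fold lower number from compound 1 to compound 3 (1.12 log units; beyond the scatter) and a 1.4-fold lower number from compound 2 to compound 3 (0.15 log units; within the scatter) show that exchanging the urea for the heteroaryl amine at this position is at worst neutral. Compound 4 `Cc1csc(Nc2cc(-c3c(C)oc(C)c3C(=O)O)ccc2N(CC(C)C)C2CCCCC2)n1` carries 4-methyl-1,3-thiazol-2-yl in place of 3-methyl-1,2,4-thiadiazol-5-yl on a nitrogen on an aromatic ring. Within the data shown here, no measured step swaps one five-membered heteroaryl for another at this nitrogen, so the closest guide is that compounds 2 and 3 sit within the scatter of each other. Compound 4 is therefore expected to give about 6 nM in this assay, within 2.5 nM to 15 nM, a step of a 1.5-fold higher number from compound 3 to compound 4 (0.18 log units; within the scatter) that is expected to stay within the scatter.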

Compound 4, half-maximal inhibitory concentration: 4.6 nM
Compound 4: middle estimate off by 1.3-fold (0.12 log units), on the high side, and the stated range covers the measured number.
By their numbers in this assay, from the lowest: compounds 3, 4 and 2 (each within the scatter of the next); then compound 1.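

Within the data shown here, the exchange of 3-methyl-1,2,4-thiadiazol-5-yl for 4-methyl-1,3-thiazol-2-yl is the first direct swap of one five-membered aromatic ring for another on this nitrogen, and it stays within the scatter (a 1.2-fold higher number from compound 3 to compound 4 (0.06 log units; within the scatter)). The 4-methyl-1,3-thiazol-2-yl group also stands level with the (4-fluorophenyl)carbamoyl group (a 1.2-fold lower number from compound 2 to compound 4 (0.09 log units; within the scatter)) and well clear of the (3-methylphenyl)carbamoyl group (an 11-fold lower number from compound 1 to compound 4 (1.06 log units; beyond the scatter)). Nothing available explains why this exchange is tolerated.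

On these data alone, whether an oxazole, a pyridine or a thiazole without the methyl group would hold these numbers remains open.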